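Iodo in Place of Nitro, Tried on a Second Core

This account rests on a few compounds, and the source may have more. Where it says the series, first, only, none or still open, it means among the compounds named here.

Compound 1 `O=[N+]([O-])c1ccc(-c2nn(-c3ccccc3)cc2C(Nc2nc3ccccc3s2)c2c(O)ccc3ccccc23)cc1` and compound 2 `Oc1ccc2ccccc2c1C(Nc1nc2ccccc2s1)c1cn(-c2ccccc2)nc1-c1ccc(I)cc1` share one core. In a functional assay on A549 cells (Homo sapiens) for antiproliferative activity, read by MTT assay, with a stated time of 48 h (a higher number here means a weaker inhibitor, a lower number a stronger inhibitor), compound 1 gives 41300 nM, and compound 2 gives 23100 nM. One change separates them, (iodo in place of nitro on an aromatic carbon), and it brought a 1.8-fold lower number from compound 1 to compound 2 (0.25 log units; within the scatter). Compound 3 `COc1ccc2nc(NC(c3cn(-c4ccccc4)nc3-c3cccc([N+](=O)[O-])c3)c3c(O)ccc4ccccc34)sc2c1` rests on another core; how its core differs from that of compound 1 is not broken down here. In this assay compound 3 gives 52200 nM. Compound 4 `COc1ccc2nc(NC(c3cn(-c4ccccc4)nc3-c3cccc(I)c3)c3c(O)ccc4ccccc34)sc2c1` arises from compound 3 by the same kind of change, (iodo in place of nitro on an aromatic carbon), the place being meta to a large group where it was para to a large group before. Because the earlier step of a 1.8-fold lower number from compound 1 to compound 2 (0.25 log units; within the scatter) stayed within the scatter, compound 4 is expected to move by a step of similar size, a 1.7-fold lower number from compound 3 to compound 4 (0.24 log units; within the scatter). Compound 4 is thus estimated at 30000 nM in this assay, between 12000 nM and 75000 nM.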

Compound 4, half-maximal inhibitory concentration: 39300 nM
The estimate for compound 4 lay 1.3-fold (0.12 log units) below the measured number; measured number inside the range.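

In this assay, iodo in place of nitro gave a 1.3-fold lower number from compound 3 to compound 4 (0.12 log units; within the scatter), so on this second core, as on the first, the step stays within the scatter. The change carries from one core to the other without a difference that can be told apart: the same change on two cores in this assay, a 1.8-fold lower number (0.25 log units; within the scatter) from compound 1 to compound 2 and a 1.3-fold lower number (0.12 log units; within the scatter) from compound 3 to compound 4, 1.3-fold (0.13 log units) apart, within the scatter of two such steps. For the compounds shown here, this shows only that the step stayed small on both cores, not that the change itself moves the number on either one, and two cores cannot establish a rule for the whole series.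

The compounds shown leave open how an amine or a carboxylic acid in place of the nitro would read in this assay. They also leave open whether the step would stay this small on a further core.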